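The source may hold more compounds than are shown below. What is called first, only, known or untested is meant among the compounds shown, and "the series" means these compounds.

Compound 1 `COc1ccc(N2C(=O)NC3(CSC4=C3C(=O)c3ncccc3C4=O)C2=O)cc1`: 650 nM in a functional assay on SF-268 cells (Homo sapiens) for antiproliferative activity, read by MTT assay, with a stated time of 96 h; a lower number here means a stronger inhibitor, a higher number a weaker inhibitor
Compound 2 `CCN(CC)c1ccc(N2C(=O)NC3(CSC4=C3C(=O)c3ncccc3C4=O)C2=O)cc1`: 960 nM in this assay
Compound 3 `CCCCc1ccc(N2C(=O)NC3(CSC4=C3C(=O)c3ncccc3C4=O)C2=O)cc1`: 400 nM in this assay

All three compounds share one core and differ only in the group attached to an aromatic carbon of the outer benzene ring. For the measured compounds named here, compound 3 gives the lowest of the three numbers, but the step of a 1.6-fold lower number from compound 1 to compound 3 (0.21 log units; within the scatter) lies within the scatter, so compound 1 and compound 3 cannot be ranked against each other; only the step of a 2.4-fold lower number from compound 2 to compound 3 (0.38 log units; beyond the scatter) goes beyond the scatter, and it is modest. Compound 4 `CC(C)(C)c1ccc(N2C(=O)NC3(CSC4=C3C(=O)c3ncccc3C4=O)C2=O)cc1` has not yet been measured. It differs from compound 3 as follows: tert-butyl in place of butyl on an aromatic carbon. Going by the values given here, none of the measured steps exchanges one four-carbon group for another of the same size. The steps of a 1.5-fold higher number from compound 1 to compound 2 (0.17 log units; within the scatter) and a 1.6-fold lower number from compound 1 to compound 3 (0.21 log units; within the scatter) replace a methoxy group, and a 2.4-fold lower number from compound 2 to compound 3 (0.38 log units; beyond the scatter) replaces a diethylamino group; all of them moved the number only a little. For a change in which the same four carbons are merely joined differently, no step beyond the scatter is expected in this assay in either direction. Compound 4 is therefore estimated to give 450 nM, with a range from 200 nM to 1000 nM, a step of a 1.1-fold higher number from compound 3 to compound 4 (0.05 log units; within the scatter).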

Compound 4, half-maximal inhibitory concentration: 500 nM
Beside the measured number, compound 4's estimate is 1.1-fold (0.05 log units) below it, and the stated range covers the measured number.
By their numbers in this assay, from the lowest: compounds 3, 4, 1 and 2 (each within the scatter of the next, the first and the last beyond it).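

Joining the same four carbons differently, so that the straight butyl chain on the aromatic carbon becomes a branched tert-butyl group, gives a 1.3-fold higher number from compound 3 to compound 4 (0.10 log units; within the scatter) in this assay and so leaves the number within ordinary repeat variation. Tert-butyl also cannot be ranked against the other two groups at this position, given a 1.3-fold lower number from compound 1 to compound 4 (0.11 log units; within the scatter) and a 1.9-fold lower number from compound 2 to compound 4 (0.28 log units; within the scatter) in the same read-out. Butyl and diethylamino remain the only pair separated beyond the scatter, by a 2.4-fold lower number from compound 2 to compound 3 (0.38 log units; beyond the scatter) and even that step is modest, while tert-butyl falls within the scatter of both, and nothing available here explains why these numbers fall as they do.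

The four groups shown span only a narrow range of numbers, so it remains open whether a carboxylic acid, a primary amine, a single fluorine atom or a much longer chain such as octyl at this same position would move the number beyond the scatter. From the compounds shown here alone, it also remains open whether the same small differences would appear in cell lines other than this one, or whether changes to the shared core matter more than changes on the outer benzene ring.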